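The source may report more compounds than this note shows. Statements on the series, on what has been measured and on what is new or still open speak of the compounds shown alone.

Compound 3 `C=C(C(=O)c1ccc(OC)cc1)C(OC(=O)c1ccccc1)c1ccccc1F` gives 34200 nM in a functional assay on MCF7 cells (Homo sapiens) for inhibition, read by XTT assay, with a stated time of 48 h (on this read-out higher numbers stand for weaker inhibition and lower numbers for stronger inhibition), the highest of the three numbers recorded. Compound 2 `C=C(C(=O)c1ccc(OC)cc1)C(OC(C)=O)c1ccccc1F` gives 18000 nM in this assay, and the step of a 1.9-fold higher number from compound 2 to compound 3 (0.28 log units; within the scatter) stays within the scatter. Compound 1 `COc1ccc(C(=O)/C(=C/C2CCCCC2)COC(=O)c2ccccc2)cc1` gives 13700 nM in this assay, a gap to compound 3 that lies beyond the scatter. Compound 4 `C=C(C(=O)c1ccc(OC)cc1)C(OC(=O)c1ccccc1)c1ccc([N+](=O)[O-])cc1` has not yet been measured. It differs from compound 3 by 4-nitrophenyl in place of 2-fluorophenyl on a saturated chain carbon bound to a double-bonded chain carbon and an oxygen next to a carbonyl group. No measured pair among these three compounds changes the aryl group on that saturated chain carbon; the only single-point step available, from compound 2 to compound 3, concerns the ester carbon and is itself within the scatter. The data therefore give no direction for the new change, and the number for compound 4 is expected to stay near that of compound 3, with a step of a 1.1-fold lower number from compound 3 to compound 4 (0.06 log units; within the scatter) that is not expected to exceed the scatter. Compound 4 is estimated at 30000 nM in this assay, within a range from 10000 nM to 90000 nM.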

Compound 4, half-maximal inhibitory concentration: 56100 nM
The estimate for compound 4 lay 1.9-fold (0.27 log units) below the measured number; low and high end bracket the measured number.
By their numbers in this assay, from the lowest: compounds 1, 2, 3 and 4 (each within the scatter of the next, the first and the last beyond it).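

Compound 3 and compound 4 form the first pair shown that changes the aryl group on a saturated chain carbon bound to a double-bonded chain carbon and an oxygen next to a carbonyl group. In this assay, among the compounds shown here, 4-nitrophenyl in place of 2-fluorophenyl gives a 1.6-fold higher number from compound 3 to compound 4 (0.21 log units; within the scatter), so this exchange of aryl groups produces no step that can be told from the scatter. Nothing available explains this outcome.

The compounds shown leave open whether an unsubstituted phenyl, or a phenyl carrying an amine or a carboxylic acid, at this place would give a step beyond the scatter. They also leave open whether the same exchange would give a similar step with methyl in place of phenyl on the ester carbonyl carbon, as in compound 2.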